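The source may hold more compounds than are shown below. What is called first, only, known or untested is meant among the compounds shown, and "the series" means these compounds.

Measured so far:
compound 1 `COc1cc2c(Oc3ccc(NC(=O)c4nn(-c5ccccc5OC(F)(F)F)c(=O)cc4C)cc3F)ccnc2cc1OCCCN1CCN(C)CC1` in a functional assay on MKN-45 cells (Homo sapiens) for inhibition, read by MTT assay, with a stated time of 72 h (on this read-out higher numbers stand for weaker inhibition and lower numbers for stronger inhibition), gives 100 nM
compound 2 `COc1cc2c(Oc3ccc(NC(=O)c4nn(-c5cccc(F)c5)c(=O)cc4C)cc3F)ccnc2cc1OCCCN1CCCC1` in this assay gives 120 nM
compound 3 `COc1cc2c(Oc3ccc(NC(=O)c4nn(-c5cccc(F)c5)c(=O)cc4C)cc3F)ccnc2cc1OCCCN1CCC(C)CC1` in this assay gives 140 nM

Compound 3 gives the highest of the three numbers, but its gaps to compound 2 and to compound 1 are both within the scatter, so the three compounds cannot be separated on these data. Among the compounds with values here, the one single-change step among them runs from compound 2 to compound 3, where the ring at the end of the propoxy chain is exchanged: a 1.2-fold higher number from compound 2 to compound 3 (0.07 log units; within the scatter).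

Compound 4 `COc1cc2c(Oc3ccc(NC(=O)c4nn(-c5cccc(F)c5)c(=O)cc4C)cc3F)ccnc2cc1OCCCN1CCN(C)CC1` differs from compound 3 as follows: 4-methylpiperazin-1-yl in place of 4-methylpiperidin-1-yl on a saturated chain carbon, three bonds along the chain from an oxygen on an aromatic ring. Within the data shown here, compound 1 carries the same 4-methylpiperazin-1-yl group on the chain but differs from compound 4 elsewhere as well, so no single step connects that pair; its value lies close to those of compound 2 and compound 3.

Among the measured compounds shown here, the only measured exchange at this chain end, from compound 2 to compound 3, left the number within the scatter. An exchange of similar size at the same place is expected to behave the same way in this assay, with no step beyond the scatter in either direction. Compound 4 is therefore estimated at 120 nM, with a range of 60 nM to 250 nM. The expected step is a 1.2-fold lower number from compound 3 to compound 4 (0.07 log units; within the scatter).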

Compound 4, half-maximal inhibitory concentration: 120 nM
For compound 4 middle estimate and measured number coincide at the digits printed, and the stated range covers the measured number.
By their numbers in this assay, from the lowest: compounds 1, 2, 4 and 3 (each within the scatter of the next).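

Working notes on the series. In this assay, the chain end now has three groups compared at one place, pyrrolidin-1-yl, 4-methylpiperidin-1-yl and 4-methylpiperazin-1-yl, and the two new steps there, a 1.2-fold lower number from compound 3 to compound 4 (0.07 log units; within the scatter) and no change at the digits printed from compound 2 to compound 4 (within the scatter), both stay within the scatter, so this place has so far tolerated each of these saturated rings, including the swap of one ring carbon for a second ring nitrogen. The first step read on an aromatic nitrogen, a 1.2-fold higher number from compound 1 to compound 4 (0.08 log units; within the scatter), also stays within the scatter, so with 4-methylpiperazin-1-yl on the chain, 3-fluorophenyl and 2-(trifluoromethoxy)phenyl cannot be told apart. No available measurement bears on why these steps remain this small.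

On these data alone, all of these chain ends are saturated nitrogen rings on the same three-carbon chain, so it remains open whether an open-chain dimethylamino group, a morpholin-4-yl ring, a terminal hydroxyl or a longer chain would give a step beyond the scatter. On the aromatic nitrogen, an unsubstituted phenyl or a pyridinyl ring would test whether that place is equally insensitive.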